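Extending the ethyl chain on the indole core

The source may report more compounds than this note shows. Statements on the series, on what has been measured and on what is new or still open speak of the compounds shown alone.

Measured compounds:
compound 1 `CCc1[nH]c2ccc(Cl)cc2c1C1=CCNCC1` — 30 nM
compound 2 `Cc1[nH]c2ccc(Cl)cc2c1C1=CCN(C)CC1` — 10 nM
compound 3 `Cc1[nH]c2ccc(Cl)cc2c1C1=CCN(Cc2ccccc2)CC1` — 600 nM

In an in vitro assay on HEK293 cells for displacement of a labelled ligand from 5-hydroxytryptamine receptor 6 (Homo sapiens) (a lower number here means a stronger inhibitor, a higher number a weaker inhibitor), compound 1 gives 30 nM, the second highest of the three numbers. Compound 2 gives 10 nM, and compound 3 gives 600 nM; compound 1 sits between them, closer to compound 2.

The unmeasured compound 4 `CCCc1[nH]c2ccc(Cl)cc2c1C1=CCNCC1` differs from compound 1 by methyl in place of hydrogen on a saturated chain carbon, two bonds along the chain from an aromatic carbon, so the change is ethyl to propyl on the core.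

Going by the values given here, only one step is known: a 60-fold higher number from compound 2 to compound 3 (1.78 log units; beyond the scatter). That change sits on the amine nitrogen of the saturated ring, not on the carbon chain attached to the aromatic core, and nothing measured here tests lengthening that chain. Compounds 1 and 2 differ in two places at once, so their values cannot be read as a single step.

Without a bearing step, compound 4 is expected to stay near compound 1, with no change beyond the scatter; the estimated step is a 1.3-fold higher number from compound 1 to compound 4 (0.12 log units; within the scatter). Compound 4 is therefore estimated at 40 nM, in the range 15 nM to 120 nM.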

Compound 4, half-maximal inhibitory concentration: 40 nM
The estimate for compound 4 equals the measured number at the digits printed; low and high end bracket the measured number.
By their numbers in this assay, from the lowest: compound 2; then compounds 1 and 4 (each within the scatter of the next); then compound 3.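

In this assay, the change from ethyl to propyl on the core gives a 1.3-fold higher number from compound 1 to compound 4 (0.12 log units; within the scatter) and lies within the scatter, so the numbers of the two compounds cannot be told apart. This is the one step shown on the carbon chain attached to the aromatic core, and it shows that a methyl in place of hydrogen, on a saturated chain carbon two bonds along the chain from an aromatic carbon, leaves the number effectively unchanged, unlike the large step seen earlier at the amine nitrogen of the saturated ring. Nothing at hand explains this result.

Going by these compounds, how far this holds remains open: a butyl chain or a cyclopropyl group at this place could read differently. On these data alone, whether propyl would also leave the number unchanged alongside a methyl on the ring nitrogen also stays open.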